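This account rests on a few compounds, and the source may have more. Where it says the series, first, only, none or still open, it means among the compounds named here.

Within the data shown here, in a functional assay on NALM-6 cells (Homo sapiens) for cytotoxicity, with a stated time of 72 h (a higher number here means that more compound is needed for the effect, a lower number that less compound is needed), compound 1 `C=C[C@@](C)(/C=C/c1ccc(O)c(/C=C/C(=O)OCC)c1)CCC=C(C)C` gives 20900 nM, the only true number available so far. In this assay, compound 2 `C=C[C@@](C)(/C=C/c1ccc(O)c(/C=C/C(=O)NCc2ccc(C(F)(F)F)cc2)c1)CCC=C(C)C` gives only a limit, > 43400 nM, and not a number. That leaves a single measured value as an anchor.

Compound 3 `C=C[C@@](C)(/C=C/c1ccc(O)c(/C=C/c2ccc(F)cc2)c1)CCC=C(C)C` has not yet been measured. Its difference from compound 1 is 4-fluorophenyl in place of ethoxycarbonyl on a double-bonded chain carbon bound to a double-bonded chain carbon. Among the measured compounds shown here, no measured pair of compounds shows what such an exchange does, so the expectation rests on compound 1 at 20900 nM, with no shift beyond the scatter foreseen in this assay in either direction. The expected step is a 1.0-fold lower number from compound 1 to compound 3 (0.02 log units; within the scatter). Compound 3 is estimated at 20000 nM, with an expected range from 8000 nM to 43000 nM.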

Compound 3, half-maximal effective concentration: > 43400 nM
Compound 3: no number, only a limit (the forecaster's own chance of this, stated with the estimate: 25%); middle value at least 2.1-fold (0.33 log units) away from the limit.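

In this assay, 4-fluorophenyl in place of ethoxycarbonyl on a double-bonded chain carbon bound to a double-bonded chain carbon gives an at least 2.0-fold higher number from compound 1 to compound 3 (0.31 log units; beyond the scatter). Among these compounds, this is the first readable step at this position, and it shows that the group placed here matters: the aromatic ring does not preserve the number of compound 1. Compound 3 has only a limit and not a number, so the step gives a minimum and its true size remains unknown: the limit of > 43400 nM in this assay, at which 2 of the 3 values shown sit.

The compounds shown leave open whether any group at this position can bring the number under that of compound 1, which gives 20900 nM. They also leave open what a carboxylic acid or an amine would do in place of ethoxycarbonyl, and whether unsubstituted phenyl would differ from 4-fluorophenyl.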